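A few compounds are considered here, and "the series" means these few. Any claim that something is new, unique, unknown or untested is made for them only; others in the source may bear on it.

Series notes. Compound 1 `Cc1ccc(/C=C2\CN(C(=S)SCc3cn(Cc4ccc(F)cc4)nn3)C/C(=C\c3ccc(C)cc3)C2=O)cc1` carries a 4-fluorobenzyl arm; in a functional assay on PC-3 cells (Homo sapiens) for cytotoxicity, read by MTT assay, with a stated time of 24 h (on this read-out lower numbers stand for stronger inhibition and higher numbers for weaker inhibition), compound 1 gives 45500 nM. Compound 2 `Cc1ccc(/C=C2\CN(C(=S)SCc3cn(Cc4ccccc4F)nn3)C/C(=C\c3ccc(C)cc3)C2=O)cc1` differs only by 4-fluorophenyl in place of 2-fluorophenyl on a saturated chain carbon bound to an aromatic nitrogen. For compound 2 the read-out in this assay is a limit, > 80000 nM, and not a number. The step of an at least 1.7-fold lower number from compound 2 to compound 1 (0.24 log units; that floor lies within the scatter) therefore rests on that limit, as the limit of > 80000 nM in this assay, at which 2 of the 3 values shown sit, makes plain. Compound 3 `O=C1/C(=C/c2ccccc2F)CN(C(=S)SCc2cn(Cc3ccccc3F)nn2)C/C1=C\c1ccccc1F` has a different core; how the core of compound 3 differs from that of compound 2 is not broken down here. For compound 3 this assay likewise reports only a limit, > 80000 nM, again one of the two values sitting at the limit of > 80000 nM in this assay, at which 2 of the 3 values shown sit.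

Compound 4 `O=C1/C(=C/c2ccccc2F)CN(C(=S)SCc2cn(Cc3ccc(F)cc3)nn2)C/C1=C\c1ccccc1F` is not yet measured; it differs from compound 3 by 4-fluorophenyl in place of 2-fluorophenyl on a saturated chain carbon bound to an aromatic nitrogen, the same change as that from compound 2 to compound 1. Because the step of an at least 1.7-fold lower number from compound 2 to compound 1 (0.24 log units; that floor lies within the scatter) was a lowering whose floor lies within the usual scatter, the step from compound 3 to compound 4 is expected to be of similar modest size, an at least 1.3-fold lower number from compound 3 to compound 4 (0.12 log units; that floor lies within the scatter), though compound 3 itself is known only as a limit. Compound 4 is thus estimated at 60000 nM in this assay, within 25000 nM to 150000 nM.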

Compound 4, half-maximal inhibitory concentration: > 80000 nM
Compound 4 gave a limit, no number; the forecaster's own chance of this, stated with the estimate: 45%; middle value at least 1.3-fold (0.12 log units) from the limit.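

In this assay, within the data shown here, compound 3 and compound 4 both give only a limit, so no step between them can be read: the limit of > 80000 nM in this assay, at which 3 of the 4 values shown sit. The compounds shown leave open whether the change from 2-fluorobenzyl to 4-fluorobenzyl alters the read-out at all on the core of compound 3, and where compound 3 and compound 4 lie beyond that limit.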